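The source may report more compounds than this note shows. Statements on the series, on what has been measured and on what is new or still open speak of the compounds shown alone.

Measured in an ADME assay on HEp-2 cells (Homo sapiens) for cytotoxicity; on this read-out lower numbers stand for higher toxicity in this test and higher numbers for lower toxicity in this test:
- compound 1 `CCc1cc2ccccc2n(Cc2nc3ccccc3n2CCCCF)c1=O` gives 85100 nM
- compound 2 `N#CCCCCn1c(CN2C(=O)CCc3ccccc32)nc2ccccc21` gives 27100 nM
- compound 3 `CCOC(=O)c1c(OC)c(=O)n(Cc2nc3ccccc3n2CCCCF)c2ccccc12` gives 61600 nM

Of these three numbers, compound 2 holds the lowest, and its gaps up to compound 3 and up to compound 1 both lie beyond the scatter. Compound 4 `CN(C)CCn1c(CN2C(=O)CCc3ccccc32)nc2ccccc21` has not yet been measured in this assay. It differs from compound 2 in one place: dimethylamino in place of 2-cyanoethyl on a saturated chain carbon, two bonds along the chain from an aromatic nitrogen. Dimethylamino stands in place of 2-cyanoethyl on a saturated chain carbon, two bonds along the chain from an aromatic nitrogen. The same difference can also be read as 4-cyanobutyl to 2-(dimethylamino)ethyl.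

Within the data shown here, no two measured compounds differ in only one place, so the data hold no direct precedent for this change. Among the measured compounds shown here, the best anchor is compound 2 at 27100 nM, the only measured compound that shares the rest of the structure of compound 4. No step beyond the scatter is therefore expected, and any drift is expected to be slight and towards a lower number. The expected step is a 1.4-fold lower number from compound 2 to compound 4 (0.13 log units; within the scatter), though this estimate is loose. For compound 4 the estimated value is 20000 nM, with an expected range from 7000 nM to 60000 nM.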

Compound 4, half-maximal cytotoxic concentration: 153000 nM
For compound 4 the middle estimate is 7.7-fold (0.88 log units) below the measured one; measured number above the stated range.
By their numbers in this assay, from the lowest: compound 2; then compounds 3, 1 and 4 (each within the scatter of the next, the first and the last beyond it).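

In this assay, dimethylamino in place of 2-cyanoethyl on a saturated chain carbon, two bonds along the chain from an aromatic nitrogen, gives a 5.6-fold higher number from compound 2 to compound 4 (0.75 log units; beyond the scatter). Among these compounds, this is the first comparison in these data between compounds that differ in one place, and it shows that, with the rest of the structure held fixed, a change at this position alone can move the read-out beyond the scatter, here towards lower toxicity in this test. Nothing available accounts for the size or the direction of this step.

This single pair cannot separate the entry of the dimethylamino group from the loss of the nitrile, and the same difference can also be read as 4-cyanobutyl to 2-(dimethylamino)ethyl, so the chain length is tied up in it as well. Open too, from the compounds shown here alone, are how a 4-(dimethylamino)butyl chain, a morpholine or a carboxylic acid would read at this position, and whether the dimethylamino change would give a similar step on the cores of compound 1 and compound 3.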